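The source may hold more compounds than are shown below. What is called first, only, known or untested is meant among the compounds shown, and "the series" means these compounds.

Measured compounds:

Compound 1 `Cc1ccc2c(c1)C=C(CC1CN=CN1)CC2` — in a functional assay for binding affinity to Norepinephrine transporter (Rattus norvegicus), read by radioligand binding, in the presence of a further agent that is not named here (on this read-out higher numbers stand for weaker inhibition and lower numbers for stronger inhibition), compound 1 gives 1000 nM.
Compound 2 `NC1=NCC(CC2=Cc3ccccc3CC2)O1` — in this assay compound 2 gives 1000 nM.

Compound 2 stands level with compound 1 on these numbers: the two values are the same at the digits reported, and no difference between them can be read from the data. The two compounds differ in more than one place, so their pair says nothing about any single change on its own; it shows only that both land at the same figure.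

The step considered here leads from compound 2 to compound 3 `Cc1ccc2c(c1)C=C(CC1CN=C(N)O1)CC2`. The change is small: methyl in place of hydrogen on an aromatic carbon. The shared core and the ring that carries the amine are kept as in compound 2.

Within the data shown here, no measured pair isolates this change, so no step of known size stands behind it. On what the two values show, there is no ground to expect the added methyl to move the figure. The expected step of no change at the digits printed from compound 2 to compound 3 (within the scatter) is therefore none beyond the scatter. For compound 3 the estimate in this assay is 1000 nM, with a range from 400 nM to 2500 nM.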

Compound 3, inhibition constant: < 1000 nM
Compound 3 ended at the assay's limit; the forecaster's own chance of this, stated with the estimate: 5%; the middle value lies on the limit itself.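

In this assay compound 3 gives < 1000 nM and this is a limit of the assay, not a number. Methyl in place of hydrogen on this aromatic carbon, meta to a fused ring and para to a fused ring, gives a number no higher from compound 2 to compound 3 (the limit leaves the size open), so the change gives no sign of weaker inhibition. A group of 6 heavy atoms in place of a group of 5 heavy atoms, on a saturated chain carbon bound to a double-bonded ring carbon, gives a number no higher from compound 1 to compound 3 (the limit leaves the size open). Neither step can be read in size. This is the only such reading among the compounds shown: the limit of < 1000 nM in this assay, at which 1 of the 3 values shown sits.

Going by these compounds, how far past the limit compound 3 truly lies stays open, so the methyl may bring a real gain or almost none. Nor do the compounds shown tell what a longer chain such as ethyl, or a methoxy group or a chlorine atom, would do on the same aromatic carbon.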